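This account rests on a few compounds, and the source may have more. Where it says the series, first, only, none or still open, it means among the compounds named here.

Values so far in a functional assay on M21 cells (Homo sapiens) for antiproliferative activity, read by sulforhodamine B assay, with a stated time of 48 h (on this read-out higher numbers stand for weaker inhibition and lower numbers for stronger inhibition), are these
Compound 1 `CN1CCN(c2ccc(S(=O)(=O)Oc3cc(Cl)c(Cl)cc3Cl)cc2)C1=O` gives 420 nM 
Compound 2 `CCN1CCN(c2ccc(S(=O)(=O)Oc3ccccc3OC)cc2)C1=O` gives > 100000 nM as a limit
Compound 3 `CCCN1CCN(c2ccc(S(=O)(=O)Oc3cc(Cl)c(Cl)cc3Cl)cc2)C1=O` gives 15000 nM 

For the measured compounds named here, compound 3 holds the higher of the two actual numbers, and a 36-fold higher number from compound 1 to compound 3 (1.55 log units; beyond the scatter) is the only measured step, a large one. That step alters the chain, not the group on the oxygen. Compound 4 `CCCN1CCN(c2ccc(S(=O)(=O)Oc3ccc(C)cc3)cc2)C1=O` keeps the chain of compound 3 and changes that group, with 4-methylphenyl in place of 2,4,5-trichlorophenyl on an oxygen. Going by the values given here, no measured step covers this swap. Compound 2 also lacks the 2,4,5-trichlorophenyl and differs elsewhere too, so its > 100000 nM, which is a limit, gives only a weak hint that a higher number is to be expected in this assay. The estimated move is modest, a 2.0-fold higher number from compound 3 to compound 4 (0.30 log units; within the scatter), and is very uncertain. For compound 4 the expected value is 30000 nM, with an estimated range from 6000 nM to 100000 nM.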

Compound 4, half-maximal inhibitory concentration: 28000 nM
For compound 4 the middle estimate is 1.1-fold (0.03 log units) above the measured one, within the range that was stated.
By their numbers in this assay, from the lowest: compound 1; then compounds 3 and 4 (each within the scatter of the next). At a limit, above all of these: compound 2.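

The swap at the oxygen bound to the sulfonyl sulfur now has a measured step in this assay, and it stays within the scatter: a 1.9-fold higher number from compound 3 to compound 4 (0.27 log units; within the scatter). With the chain of compound 3, 2,4,5-trichlorophenyl and 4-methylphenyl therefore cannot be told apart in this assay. Removing all the chlorine atoms from this group does not, on this chain, give a difference beyond the scatter.

On these data alone, whether the same holds with the chain of compound 1, or for an amine or a carboxylic acid at this place, stays open. Compound 2 remains a limit and offers no number for comparison: the limit of > 100000 nM in this assay, at which 1 of the 4 values shown sits.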